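This account rests on a few compounds, and the source may have more. Where it says the series, first, only, none or still open, it means among the compounds named here.

Measured compounds:
Compound 1 `CC(=O)SCCC(CCCCC(=O)O)SC(C)=O` gives 9.96% in a functional assay on NCI-H460 cells (Homo sapiens) for inhibition, read by MTT assay, with a stated time of 24 h, tested at 0.1 ug/mL; on this read-out higher numbers stand for more inhibition of growth at the one concentration tested and lower numbers for less inhibition of growth.
Compound 2 `O=C(O)CCCCC(CCSC(=O)c1ccccc1)SC(=O)c1ccccc1` is reported in this assay as "not active" (no number reported), without a number.
Compound 3 `CC(=O)SCCC(CCCCC(=O)Nc1ccccc1)SC(C)=O` gives 15.4% in this assay.

The cores of compound 1 and compound 2 are different, and how they differ is not broken down here. Compound 3 arises from compound 1 by one change: anilino in place of hydroxy on a carbonyl carbon In this assay this gave a number 5.4 percentage points higher from compound 1 to compound 3 (within the scatter). Compound 4 `O=C(CCCCC(CCSC(=O)c1ccccc1)SC(=O)c1ccccc1)Nc1ccccc1`, not yet measured, arises from compound 2 by the same change: anilino in place of hydroxy on a carbonyl carbon The place of the change reads the same in both pairs. The step from compound 2 to compound 4 is expected to be small as well, since the earlier one was a number 5.4 percentage points higher from compound 1 to compound 3 (within the scatter) and compound 2 itself is reported as "not active" (no number reported). Compound 4 is therefore expected to give about 8% in this assay, between 0% and 20%.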

Compound 4, percent growth inhibition at one concentration: 0.6%
The estimate for compound 4 lay 7.4 percentage points above the measured number; low and high end bracket the measured number.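

In this assay, among these compounds, compound 2 has no number, and no step from it to compound 4 can be read. Nothing measured here points to a cause for this result. The compounds shown leave open whether anilino in place of hydroxy changes growth inhibition in the same way on both cores.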